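Trading 3,5-difluorophenyl for 4-fluorophenyl

The source may hold more compounds than are shown below. What is called first, only, known or untested is meant among the compounds shown, and "the series" means these compounds.

In a functional assay on HL-60 cells (Homo sapiens) for inhibition, read by MTT assay, with a stated time of 48 h, tested at 10 uM (on this read-out higher numbers stand for more inhibition of growth at the one concentration tested and lower numbers for less inhibition of growth), compound 3 `Cc1oc2c([C@H]3CCN(C)C[C@H]3O)c(O)cc(O)c2c(=O)c1C(O)c1cc(F)cc(F)c1` gives 30% and compound 1 `Cc1oc2c([C@H]3CCN(C)C[C@H]3O)c(O)cc(O)c2c(=O)c1C(O)c1ccc(F)c(Br)c1` gives 25%, two values within the scatter of each other, while compound 2 `Cc1oc2c([C@H]3CCN(C)C[C@H]3O)c(O)cc(O)c2c(=O)c1C(O)c1c(Cl)cccc1Cl` gives 14%. Compound 4 `Cc1oc2c([C@H]3CCN(C)C[C@H]3O)c(O)cc(O)c2c(=O)c1C(O)c1ccc(F)cc1` differs from compound 3 in one place: 4-fluorophenyl in place of 3,5-difluorophenyl on a saturated chain carbon bound to an aromatic carbon and an oxygen on a saturated carbon. Three measured swaps of the group at this same place bear on it. One gives a number 5 percentage points higher from compound 1 to compound 3 (within the scatter), and the others give a number 11 percentage points lower from compound 1 to compound 2 (beyond the scatter) and a number 16 percentage points higher from compound 2 to compound 3 (beyond the scatter). Only the two steps that involve compound 2 leave the scatter, and compound 2 plays no part in this change. The expected step is a number 3 percentage points lower from compound 3 to compound 4 (within the scatter), so none beyond the scatter is anticipated. Compound 4 is estimated at 27%, with an expected range from 15% to 40%.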

Compound 4, percent growth inhibition at one concentration: 30%
Compound 4: the middle estimate sits 3 percentage points below what was measured; low and high end bracket the measured number.
By their numbers in this assay, from the lowest: compound 2; then compounds 1, 3 and 4 (each within the scatter of the next).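

In this assay, 4-fluorophenyl in place of 3,5-difluorophenyl gives no change at the digits printed from compound 3 to compound 4 (within the scatter) and hydrogen in place of bromo gives a number 5 percentage points higher from compound 1 to compound 4 (within the scatter) so neither the second fluorine nor the bromo is needed to hold this level of growth inhibition. Only 2,6-dichlorophenyl stands apart, with a number 16 percentage points higher from compound 2 to compound 4 (beyond the scatter) and the 4-fluorophenyl group now joins the other two groups above it. Nothing available explains these steps.

Going by these compounds, whether a plain phenyl, with no halogen at all, would hold the same level stays open. So does the effect of a ring carrying an amine or a carboxylic acid.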